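The source may report more compounds than this note shows. Statements on the series, on what has been measured and on what is new or still open speak of the compounds shown alone.

In a functional assay on PANC-1 cells (Homo sapiens) for cytotoxicity, read by WST assay, with a stated time of 24 h (a higher number here means a weaker inhibitor, a lower number a stronger inhibitor), compound 1 (`O=C(CCCCCCCCCc1ccccc1)N1CCCCC1`) gives > 100000 nM as a limit of the assay. Compound 2 (`O=C(CCCCCCCCCCc1ccccc1)N1CCCCC1`) gives > 100000 nM as a limit too. Going by the values given here, that leaves a step that the two limits leave unreadable from compound 1 to compound 2 as the one measured step, and it offers no size to carry forward. Among the compounds with values here, compound 3 (`O=C(CCCCCCCCc1ccc(C(F)(F)F)cc1)N1CCCCC1`) gives 54000 nM as the only actual number in the set. The rest of the picture is the limit of > 100000 nM in this assay, at which 2 of the 3 values shown sit, and nothing firmer. Compound 4 (`N#Cc1ccc(CCCCCCCCC(=O)N2CCCCC2)cc1`) differs from compound 3 by cyano in place of trifluoromethyl on an aromatic carbon in the form of cyano in place of trifluoromethyl on an aromatic carbon, para to a large group. Within the data shown here, no measured step touches this substituent, so neither a size nor a direction can be taken over from the series. No step beyond the scatter is therefore expected in this assay on present evidence, although the reading may still come back as a limit. The estimated change is a 1.3-fold higher number from compound 3 to compound 4 (0.11 log units; within the scatter) on this basis. For compound 4 the expected value is 70000 nM with an estimated range from 35000 nM to 130000 nM as the working figure.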

Compound 4, half-maximal inhibitory concentration: > 100000 nM
Compound 4: only a limit was reported; the forecaster's own chance of this, stated with the estimate: 40%; at least 1.4-fold (0.15 log units) between middle value and limit.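

In this assay cyano in place of trifluoromethyl on an aromatic carbon, para to a large group, gives an at least 1.8-fold higher number from compound 3 to compound 4 (0.26 log units; that floor lies within the scatter). Going by these compounds alone, this is the first step at this position that can be read at all, but it is only a floor, so it does not establish a change beyond the scatter. The steps linking compound 4 to compound 1 and compound 2 cannot be read, and the series now rests largely on a single limit: the limit of > 100000 nM in this assay, at which 3 of the 4 values shown sit.

From the compounds shown here alone, it remains open whether any group at this position moves the number beyond the scatter, and how far the true value of compound 4 lies from its limit. A methoxy group or a carboxylic acid in place of trifluoromethyl, or a shorter chain with trifluoromethyl kept, would test whether this position or the chain carries the reading.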